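Swapping a Cyclopropyl for an Oxan-4-yl on the Amide

The source may hold more compounds than are shown below. What is called first, only, known or untested is meant among the compounds shown, and "the series" means these compounds.

Two measured compounds share a common core and were followed in an ADME assay (Canis lupus familiaris, strain Beagle) for pharmacokinetics; on this read-out higher numbers stand for wider distribution into tissues and lower numbers for narrower distribution. Compound 1, `CCn1ncc(-c2nc3c(N4CCC(n5c(=O)[nH]c6ncccc65)CC4)ncnc3n2C)c1C`, gives 4.6 L/kg in this assay. Within the data shown here, compound 2, `CCn1ncc(-c2nc3c(O[C@H]4CCN(C(=O)C5CC5)C4)ncnc3n2C)c1C`, gives 0.9 L/kg in this assay, the lower of the two numbers; its only neighbour is compound 1, and the gap between them lies beyond the usual scatter. Compound 3, `CCn1ncc(-c2nc3c(O[C@H]4CCN(C(=O)C5CCOCC5)C4)ncnc3n2C)c1C`, has not yet been measured. It differs from compound 2 in one place: oxan-4-yl in place of cyclopropyl on a carbonyl carbon. Read one bond further out, the change turns a cyclopropylcarbonyl into a (oxan-4-yl)carbonyl. Among the measured compounds shown here, no measured pair shows this change, so there is nothing to calibrate the step against. In this assay the step of a 1.1-fold lower number from compound 2 to compound 3 (0.05 log units; within the scatter) is expected to stay within the scatter, with no clear direction. The estimate for compound 3 in this assay is 0.8 L/kg, with a range from 0.5 L/kg to 1.4 L/kg.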

Compound 3, volume of distribution: 0.9 L/kg
Compound 3: middle estimate off by 1.1-fold (0.05 log units), on the low side; measured number inside the range.
By their numbers in this assay, from the lowest: compounds 2 and 3 (each within the scatter of the next); then compound 1.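

In this assay, among these compounds, oxan-4-yl in place of cyclopropyl on a carbonyl carbon gives no change at the digits printed from compound 2 to compound 3 (within the scatter) and is the first single-place comparison. At this place, then, a group of 6 heavy atoms with one six-membered ring and 1 hydrogen-bond acceptor can stand in for one of 3 heavy atoms with one three-membered ring and 0 hydrogen-bond acceptors, and the two compounds cannot be told apart on this read-out. No accompanying measurement offers an explanation for this result.

Among the compounds shown here, this single pair shows only two neutral ring groups at this place. From the compounds shown here alone, whether an amine such as piperidin-4-yl, a carboxylic acid or a longer chain on the same carbonyl carbon would shift the number remains open.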